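This account rests on a few compounds, and the source may have more. Where it says the series, first, only, none or still open, it means among the compounds named here.

Compound 1 `O=C(N[C@H]1CN(S(=O)(=O)c2ccccc2)C[C@@H]1C(=O)N[C@H]1CCCNC1)c1cc(-c2ccc(Cl)cc2)on1` and compound 2 `O=C(N[C@H]1CN(S(=O)(=O)c2ccccc2)C[C@@H]1C(=O)N[C@H]1CCCNC1)c1cc(-c2ccccc2Cl)on1` share one core and differ only in the chlorophenyl group on the isoxazole-bearing end. In an ADME assay on cells (Hepatocyte, Rattus norvegicus) for metabolic stability (on this read-out lower numbers stand for slow clearance and higher numbers for fast clearance), compound 1 gives 2.22 uL/min, while compound 2 gives 8.3 uL/min, the higher of the two numbers, and the step of a 3.7-fold higher number from compound 1 to compound 2 (0.57 log units; beyond the scatter) lies beyond the scatter. Compound 3 `O=C(N[C@H]1CN(S(=O)(=O)c2ccccc2)C[C@@H]1C(=O)N[C@H]1CCCNC1)c1cc(-c2ccc(Cl)cc2Cl)on1` differs from compound 2 by chloro in place of hydrogen on an aromatic carbon, the new group sitting meta to a chloro group and para to a large group, so that the 2-chlorophenyl becomes a 2,4-dichlorophenyl. Within the data shown here, only the step from compound 1 to compound 2 bears on this change, and only loosely, since it moved a chloro group rather than adding one; it shows that the chloro pattern on this ring can shift this assay by a modest amount. For compound 3 a step of about a 1.3-fold higher number from compound 2 to compound 3 (0.12 log units; within the scatter) is expected, upward but possibly within the scatter. The estimate for compound 3 in this assay is 11 uL/min, with a range from 5 uL/min to 25 uL/min.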

Compound 3, intrinsic clearance in a liver preparation (reported as CLH), per the amount of preparation that the assay uses: < 1 uL/min
Compound 3: only a limit was reported; the forecaster's own chance of this, stated with the estimate: 5%; middle value at least 11-fold (1.04 log units) away from the limit.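

Compound 3 gives only a limit of the assay in this assay: the limit of < 1 uL/min in this assay, at which 1 of the 3 values shown sits. Going from 2-chlorophenyl to 2,4-dichlorophenyl gives an at least 8.3-fold lower number from compound 2 to compound 3 (0.91 log units; beyond the scatter), so adding chloro at this position moves the number the opposite way from the change between the two single-chloro compounds, which was a 3.7-fold higher number from compound 1 to compound 2 (0.57 log units; beyond the scatter). The same addition seen from the 4-chlorophenyl side gives an at least 2.2-fold lower number from compound 1 to compound 3 (0.34 log units; beyond the scatter), so among these three compounds, the ring carrying both chloro groups gives a lower number than either single-chloro ring, by a step beyond the scatter.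

Going by these compounds, how far compound 3 truly lies under its limit remains open, and with it the full size of both steps. Also open, on these data alone, is whether a fluoro, methyl or methoxy group at this position would lower the number as chloro does.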